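The source may report more compounds than this note shows. Statements on the series, on what has been measured and on what is new or still open speak of the compounds shown alone.

Of the compounds shown here, three that share one core have been tested in an ADME assay on microsomes from liver (Homo sapiens) for metabolic stability, tested at 2.5 uM; a lower number here means slower removal, a higher number faster removal of the compound. Compound 1 `O=S(=O)(c1cccc(F)c1)c1cnc2c(F)cccc2c1-c1ccc(Cl)cc1` gives 0.62 mL/min in this assay. Compound 2 `O=S(=O)(c1cc(Cl)cc(Cl)c1)c1cnc2c(F)cccc2c1-c1ccc(F)cc1` gives 1.01 mL/min. Compound 3 `N#Cc1cccc(S(=O)(=O)c2cnc3c(F)cccc3c2-c2ccc(F)cc2)c1` gives 0.19 mL/min, the lowest of the three numbers; its nearest neighbour is compound 1, and compound 2 is furthest from it.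

Within the data shown here, the only single-point step among the measured compounds runs a 5.3-fold lower number from compound 2 to compound 3 (0.73 log units; beyond the scatter).

Compound 4 `O=S(=O)(c1cccc(F)c1)c1cnc2c(F)cccc2c1-c1ccc(F)cc1` has not yet been measured in this assay. It differs from compound 3 in one place: fluoro in place of cyano on an aromatic carbon

The step from compound 2 to compound 3 bears on this change, since it too alters the group on the sulfonyl sulfur, and going towards the 3-cyanophenyl gave the lower number. Compound 4 leaves the 3-cyanophenyl for the 3-fluorophenyl, so the direction is expected to reverse. Compound 1 also carries a 3-fluorophenyl on the sulfonyl sulfur and shows 0.62 mL/min, a higher number than compound 3, though it differs from compound 4 elsewhere as well. Compound 4 is therefore expected to show a step of a 2.9-fold higher number from compound 3 to compound 4 (0.46 log units; beyond the scatter) in this assay. The estimate for compound 4 is 0.55 mL/min, expected within a range from 0.3 mL/min to 1 mL/min.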

Compound 4, intrinsic clearance in a liver preparation (reported as CLH), per the amount of preparation that the assay uses: 0.19 mL/min
Compound 4: the middle estimate sits 2.9-fold (0.46 log units) above what was measured; the whole stated range lies above it.
By their numbers in this assay, from the lowest: compounds 3 and 4 (each within the scatter of the next); then compounds 1 and 2 (each within the scatter of the next).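

In this assay, fluoro in place of cyano gives no change at the digits printed from compound 3 to compound 4 (within the scatter), so the 3-fluorophenyl and the 3-cyanophenyl on the sulfonyl sulfur cannot be told apart here, while the earlier compounds had shown only that the 3-cyanophenyl differs from the 3,5-dichlorophenyl. The 3-fluorophenyl in place of the 3,5-dichlorophenyl gives a 5.3-fold lower number from compound 2 to compound 4 (0.73 log units; beyond the scatter) in the same assay, which matches the earlier step with the 3-cyanophenyl, and so both groups stand apart from the 3,5-dichlorophenyl by the same margin. Fluoro in place of chloro, with the 3-fluorophenyl on the sulfonyl sulfur unchanged, gives a 3.3-fold lower number from compound 1 to compound 4 (0.51 log units; beyond the scatter). No measurement at hand offers a reason for any of these steps.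

The compounds shown leave open whether the number would hold with other groups at this position on the ring, such as an amine, a carboxylic acid or a methoxy group, or with no group there at all. They also leave open whether the step from chloro to fluoro would be the same with the 3-cyanophenyl on the sulfonyl sulfur, or with the 3,5-dichlorophenyl there.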